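The source may hold more compounds than are shown below. What is called first, only, known or untested is meant among the compounds shown, and "the series" means these compounds.

Measured in a functional assay on HL-60 cells (Homo sapiens) for inhibition, read by MTT assay, with a stated time of 72 h; a higher number here means a weaker inhibitor, a lower number a stronger inhibitor:
compound 1 `Cc1nc(-c2ccccc2)c(C(=O)N2CCN(c3ccccc3C(F)(F)F)CC2)o1` gives 120 nM
compound 2 `Cc1nc(-c2ccccc2)c(C(=O)N2CCN(c3cccc(C(F)(F)F)c3)CC2)o1` gives 153 nM
compound 3 `CC(=O)Nc1cccc(N2CCN(C(=O)c3oc(C)nc3-c3ccccc3)CC2)c1` gives 329 nM

Compound 3 has the highest number of the three and is the weakest inhibitor here. Compound 4 `COc1cc(OC)cc(N2CCN(C(=O)c3oc(C)nc3-c3ccccc3)CC2)c1` carries 3,5-dimethoxyphenyl in place of 3-acetamidophenyl on an amine nitrogen in a ring. Two measured steps end at the acetamido compound, a 2.2-fold higher number from compound 2 to compound 3 (0.33 log units; beyond the scatter) and a 2.7-fold higher number from compound 1 to compound 3 (0.44 log units; beyond the scatter), and both are modest. The step of a 1.3-fold higher number from compound 1 to compound 2 (0.11 log units; within the scatter) stays within the scatter. Within the data shown here, no measured compound carries 3,5-dimethoxyphenyl, so the evidence is indirect. A small move toward a lower number, not clearly beyond the scatter, is expected, with an estimated step of a 1.6-fold lower number from compound 3 to compound 4 (0.22 log units; within the scatter) in this assay. For compound 4 the estimate is 200 nM, with an expected range from 80 nM to 500 nM.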

Compound 4, half-maximal inhibitory concentration: 19.2 nM
Compound 4: middle estimate off by 10-fold (1.02 log units), on the high side; measured number outside the range, below it.
By their numbers in this assay, from the lowest: compound 4; then compounds 1 and 2 (each within the scatter of the next); then compound 3.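

In this assay, among these compounds, the group on the amine nitrogen in a ring can shift the number much further than the earlier compounds showed: 3,5-dimethoxyphenyl in place of 3-acetamidophenyl gives a 17-fold lower number from compound 3 to compound 4 (1.23 log units; beyond the scatter), and replacing either trifluoromethyl isomer gives an 8.0-fold lower number from compound 2 to compound 4 (0.90 log units; beyond the scatter) and a 6.3-fold lower number from compound 1 to compound 4 (0.80 log units; beyond the scatter). Compound 4 is therefore the strongest inhibitor of the four. Nothing available explains this gain. Still open, as far as these compounds go, is whether a single methoxy, as in 3-methoxyphenyl, or two methyl groups, as in 3,5-dimethylphenyl, would keep the number this low.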